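A few compounds are considered here, and "the series" means these few. Any claim that something is new, unique, unknown or untested is made for them only; others in the source may bear on it.

Compound 1, `COc1cc(N(Cc2nc3ccccc3[nH]2)C(=O)c2ccc(Br)cc2)cc(OC)c1OC`, gives > 50000 nM in a functional assay on MCF7 cells (Homo sapiens) for inhibition, read by MTT assay, with a stated time of 48 h; on this read-out higher numbers stand for weaker inhibition and lower numbers for stronger inhibition; this is a limit of the assay, not a number.
Compound 2, `COc1cc(N(Cc2nc3ccccc3[nH]2)C(=O)c2cccc(Cl)c2)cc(OC)c1OC`, gives 34900 nM in this assay.

Among the two values shown, compound 2 holds the only actual number in this assay. The other value, that of compound 1, is a limit of the assay, as the limit of > 50000 nM in this assay, at which 1 of the 2 values shown sits, records.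

Compound 3, `COc1ccc(C(=O)N(Cc2nc3ccccc3[nH]2)c2cc(OC)c(OC)c(OC)c2)cc1OC`, differs from compound 2 in one place: 3,4-dimethoxyphenyl in place of 3-chlorophenyl on a carbonyl carbon. Among the compounds with values here, only one measured step bears on this change, namely an at least 1.4-fold lower number from compound 1 to compound 2 (0.15 log units; that floor lies within the scatter), which also exchanged the aryl group on the same carbonyl carbon and stayed within the scatter. Nothing measured shows that a change at this place moves the value beyond the scatter, and the 3,4-dimethoxyphenyl group itself has no measured counterpart among the compounds shown. The step is therefore expected to be small, a 1.1-fold higher number from compound 2 to compound 3 (0.06 log units; within the scatter), with a fair chance that the assay again returns only a limit rather than a number. The estimate for compound 3 in this assay is 40000 nM, with a range from 15000 nM to 150000 nM.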

Compound 3, half-maximal inhibitory concentration: > 50000 nM
Compound 3 ended at the assay's limit; the forecaster's own chance of this, stated with the estimate: 35%; middle value at least 1.2-fold (0.09 log units) from the limit.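

Compound 3 adds a second aryl exchange on the carbonyl carbon, and in this assay the change to 3,4-dimethoxyphenyl gives an at least 1.4-fold higher number from compound 2 to compound 3 (0.15 log units; that floor lies within the scatter). This group brings 2 hydrogen-bond acceptors where 3-chlorophenyl has none, yet the measured floor of the step shows no move beyond the scatter, and its true size stays unfixed. The step between compound 1 and compound 3 cannot be read, and the number for compound 2 remains the only actual number at this position, with the other two compounds resting on a limit of the assay: the limit of > 50000 nM in this assay, at which 2 of the 3 values shown sit.

On these data alone, whether any group on this carbonyl carbon can move the value beyond the scatter stays open, for instance a cyclohexyl ring, a longer alkyl chain, or a phenyl ring carrying an amine or a carboxylic acid. Within the data shown here, also open is how far compound 1 and compound 3 really lie from each other and from compound 2, as neither of the first two has a number in this assay.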